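Stereochemical inversions in a cyclic arginine-aspartate-phenylalanine series

The compounds below may be only part of what the source reports. "The series", "measured", "known", "first", "only" and "open" are said of these compounds alone.

Three stereoisomers of one cyclic peptide share all atoms and bonds and differ only in the drawn configuration of ring carbons. Compound 1 `N=C(N)NCCC[C@@H]1NC(=O)CC(=O)N[C@@H](CC(=O)O)C(=O)N[C@@H](Cc2ccccc2)CNC1=O` is the tightest binder shown: in an assay on K562 cells for inhibition of integrin alpha-5/beta-1 (Homo sapiens), with a stated time of 30 min (on this read-out higher numbers stand for weaker inhibition and lower numbers for stronger inhibition), compound 1 gives 520 nM. Compound 2 `N=C(N)NCCC[C@H]1NC(=O)CC(=O)N[C@@H](CC(=O)O)C(=O)N[C@@H](Cc2ccccc2)CNC1=O`, with one ring stereocentre inverted, gives 4700 nM, a 9.0-fold higher number from compound 1 to compound 2 (0.96 log units; beyond the scatter). Compound 3 `N=C(N)NCCC[C@H]1NC(=O)CC(=O)N[C@H](CC(=O)O)C(=O)N[C@H](Cc2ccccc2)CNC1=O` sits at the limit of this assay, reported as > 100000 nM, which is a limit and not a number. The move to compound 3 is an at least 21-fold higher number from compound 2 to compound 3 (1.32 log units; beyond the scatter) and an at least 190-fold higher number from compound 1 to compound 3 (2.28 log units; beyond the scatter).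

Compound 4 `N=C(N)NCCC[C@H]1NC(=O)CC(=O)N[C@@H](CC(=O)O)C(=O)N[C@H](Cc2ccccc2)CNC1=O` is reached from compound 3 by the two compounds have the same atoms and bonds; at least one stereo element is drawn with a configuration in one of them and without one in the other: 1 of 4 stereo elements differ; a stereocentre at a saturated ring carbon is drawn R in compound 3 and S in compound 4. Within the data shown here, the single inversion between compound 1 and compound 2 cost a modest step, and two inversions between compound 2 and compound 3 a large one, so a single inversion back is expected to recover part of that loss. Compound 4 is therefore expected to give a lower number than compound 3, with the step of an at least 2.0-fold lower number from compound 3 to compound 4 (0.30 log units; that floor lies within the scatter), though the limit on compound 3 makes the size uncertain. The estimate for compound 4 in this assay is 50000 nM, within 8000 nM to 300000 nM.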

Compound 4, half-maximal inhibitory concentration: > 100000 nM
Compound 4 was reported as a limit (the forecaster's own chance of this, stated with the estimate: 40%); at least 2.0-fold (0.30 log units) between middle value and limit.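

In this assay compound 4 is reported as > 100000 nM, which is a limit and not a number. A single inverted stereocentre at a saturated ring carbon gives an at least 21-fold higher number from compound 2 to compound 4 (1.32 log units; beyond the scatter), a large step where the single inversion in a 9.0-fold higher number from compound 1 to compound 2 (0.96 log units; beyond the scatter) was modest, so within these compounds the effect of one inversion depends on which ring carbon changes, and the two inversions in an at least 190-fold higher number from compound 1 to compound 4 (2.28 log units; beyond the scatter) reach the same limit. The step from compound 3 to compound 4 cannot be read, so this inversion shows no recovery on this read-out.

From the compounds shown here alone, how far compound 3 and compound 4 lie past the limit, and whether they differ at all, stays open. Also open, going by these compounds, is how the configuration of compound 1 would respond to a tetrazole in place of the carboxylic acid or a primary amine in place of the guanidine.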